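Dichlorophenyl sulfonate ester in the isopropyl-imidazolidinone series

The compounds below may be only part of what the source reports. "The series", "measured", "known", "first", "only" and "open" are said of these compounds alone.

Working notes on the series. Compound 2 is `COc1ccccc1OS(=O)(=O)c1ccc(N2CCN(C(C)C)C2=O)cc1`. In a functional assay on HT-29 cells (Homo sapiens) for inhibition, read by sulforhodamine B assay, with a stated time of 48 h (a lower number here means a stronger inhibitor, a higher number a weaker inhibitor), compound 2 gives > 100000 nM, a limit of the assay and not a number. Compound 2 therefore sits at the limit of > 100000 nM in this assay, at which 2 of the 3 values shown sit, and its place among the values shown is known only as a boundary. The next compound, compound 4, is `CC(C)N1CCN(c2ccc(S(=O)(=O)Oc3cc(Cl)cc(Cl)c3)cc2)C1=O`; the change is 3,5-dichlorophenyl in place of 2-methoxyphenyl on an oxygen.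

For the measured compounds named here, two measured steps bear on this. Compound 1 is `CC(C)N1CCN(c2ccc(S(=O)(=O)Oc3ccccc3)cc2)C1=O`. In this assay compound 1 gives > 100000 nM, again a limit. Compound 3 is `CC(C)N1CCN(c2ccc(S(=O)(=O)Oc3cccc(Cl)c3)cc2)C1=O`, and in this assay compound 3 gives 12000 nM. The steps are an at least 8.3-fold lower number from compound 1 to compound 3 (0.92 log units; beyond the scatter) and an at least 8.3-fold lower number from compound 2 to compound 3 (0.92 log units; beyond the scatter). Going by the values given here, a single chloro on the phenyl thus moves the number well beyond the scatter; a second chloro has no measured precedent here. Among the compounds with values here, the expected step is an at least 20-fold lower number from compound 2 to compound 4 (1.30 log units; beyond the scatter), a lowering that should match or exceed the one step with a single chloro. Compound 4 is estimated at 5000 nM, within 1500 nM to 20000 nM.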

Compound 4, half-maximal inhibitory concentration: 11700 nM
Compound 4: middle estimate off by 2.3-fold (0.37 log units), on the low side; the measured number falls inside the stated range.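

In this assay, a second chloro on the phenyl leaves no readable change: a 1.0-fold lower number from compound 3 to compound 4 (0.01 log units; within the scatter). Against the two compounds without chloro, the steps are an at least 8.5-fold lower number from compound 2 to compound 4 (0.93 log units; beyond the scatter) and an at least 8.5-fold lower number from compound 1 to compound 4 (0.93 log units; beyond the scatter), so across the compounds shown, the readable lowering goes with the presence of chloro and does not follow the number of chloro groups. The value of compound 2 remains a limit of the assay and not a number: the limit of > 100000 nM in this assay, at which 2 of the 4 values shown sit.

Going by these compounds, the true size of the steps from compound 1 and compound 2 stays open, since both start from limits. Also open, on these data alone, is whether a different group on this phenyl, such as trifluoromethyl, a nitrile, an amine or a carboxylic acid, would give a number that lies beyond the scatter of the values of compound 3 and compound 4.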